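From 3-bromopropyl to 5-bromopentyl: a small step expected

A few compounds are considered here, and "the series" means these few. Any claim that something is new, unique, unknown or untested is made for them only; others in the source may bear on it.

In a functional assay on HCT-116 cells (Homo sapiens) for antiproliferative activity, read by MTT assay, with a stated time of 48 h (a higher number here means a weaker inhibitor, a lower number a stronger inhibitor), compound 1 `COc1ccc(N(C)c2ccnc(Cl)n2)cc1` gives 1460 nM and compound 2 `COc1ccc(N(C)c2ccnc(Cl)n2)cc1[N+](=O)[O-]` gives 4700 nM while compound 3 `COc1ccc(N(C)c2ccnc(Cl)n2)cc1OCCCBr` gives 1970 nM as its value. Of these three numbers, compound 3 lies within the scatter of compound 1 and clearly apart from compound 2. Compound 4 `COc1ccc(N(C)c2ccnc(Cl)n2)cc1OCCCCCBr` extends the chain of compound 3 from 3-bromopropyl to 5-bromopentyl, with 2-bromoethyl in place of bromo on a saturated chain carbon, three bonds along the chain from an oxygen on an aromatic ring as the counted change. Among the compounds with values here, no measured step alters this chain length. The nearest evidence is a 1.3-fold higher number from compound 1 to compound 3 (0.13 log units; within the scatter) on adding 3-bromopropoxy, whereas the nitro steps, a 3.2-fold higher number from compound 1 to compound 2 (0.51 log units; beyond the scatter) and a 2.4-fold lower number from compound 2 to compound 3 (0.38 log units; beyond the scatter) in turn, are modest. No change beyond the scatter is therefore expected in this assay, and the expected result is a 1.0-fold higher number from compound 3 to compound 4 (0.01 log units; within the scatter) for this extension. Compound 4 is estimated at 2000 nM with an expected range from 900 nM to 4500 nM in this assay.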

Compound 4, half-maximal inhibitory concentration: > 10000 nM
Compound 4: only a limit was reported; the forecaster's own chance of this, stated with the estimate: 2%; at least 5.0-fold (0.69 log units) between middle value and limit.
By their numbers in this assay, from the lowest: compounds 1 and 3 (each within the scatter of the next); then compound 2. At a limit, above all of these: compound 4.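

In this assay, compound 4 carries only a limit, not a number: the limit of > 10000 nM in this assay, at which 1 of the 4 values shown sits. The chain length at this position therefore matters: going from 3-bromopropyl to 5-bromopentyl brings an at least 5.0-fold higher number from compound 3 to compound 4 (0.70 log units; beyond the scatter), although adding 3-bromopropoxy to compound 1 had stayed within the scatter. The (5-bromopentyl)oxy group brings an at least 6.8-fold higher number from compound 1 to compound 4 (0.83 log units; beyond the scatter) and, in place of nitro, an at least 2.1-fold higher number from compound 2 to compound 4 (0.32 log units; beyond the scatter). On these data alone, the full size of these steps stays open, as does whether a 4-bromobutyl chain would already show the change. Also open, as far as these compounds go, is whether an amine in place of bromo on the 5-bromopentyl chain would behave the same way.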